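The compounds below may be only part of what the source reports. "The series", "measured", "known", "first", "only" and "open" are said of these compounds alone.

Compound 2 `C[C@@H]1CN(c2ccc(C#CC(C)(O)c3nccs3)cc2Nc2ncnc3[nH]ccc23)CCN1` gives 210 nM in an assay for inhibition of mitogen-activated protein kinase kinase kinase 14 (Homo sapiens), read by luminescence and ADP-Glo, with a stated time of 120 min, in the presence of a further agent that is not named here (a lower number here means a stronger inhibitor, a higher number a weaker inhibitor), the lowest of the two numbers recorded there. Within the data shown here, the only comparison available is compound 1 `CC(O)(C#Cc1cccc(Nc2ncnc3[nH]ccc23)c1)c1nccs1`, which in this assay gives 1640 nM; the step of a 7.8-fold lower number from compound 1 to compound 2 (0.89 log units; beyond the scatter) came from placing 3-methylpiperazin-1-yl where hydrogen had been on an aromatic carbon.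

Compound 3 `CC(O)(C#Cc1ccc(OC2CCOCC2)c(Nc2ncnc3[nH]ccc23)c1)c1nccs1` has not yet been measured. It differs from compound 2 by (oxan-4-yl)oxy in place of 3-methylpiperazin-1-yl on an aromatic carbon. Only the measured step bears on this change, and it does so indirectly: it shows how much the 3-methylpiperazin-1-yl group contributed in this assay, not what (oxan-4-yl)oxy will contribute when it takes that place on the aromatic carbon. Since the entering group is of the same heavy-atom count but carries no hydrogen-bond donor, the step of a 2.4-fold higher number from compound 2 to compound 3 (0.38 log units; beyond the scatter) is expected to move toward a higher number, probably beyond the scatter but likely less than the full distance back to compound 1. Compound 3 is therefore expected to give about 500 nM in this assay, within a range of 150 nM to 1600 nM.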

Compound 3, half-maximal inhibitory concentration: 112 nM
Estimate against measurement, compound 3: 4.5-fold (0.65 log units) above; the measured number lies below the stated range.
By their numbers in this assay, from the lowest: compounds 3 and 2 (each within the scatter of the next); then compound 1.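

In this assay the exchange on this aromatic carbon gives a 1.9-fold lower number from compound 2 to compound 3 (0.27 log units; within the scatter) and so does not separate the two groups, although 3-methylpiperazin-1-yl has 1 hydrogen-bond donor and 1 defined stereocentre while (oxan-4-yl)oxy has 0 hydrogen-bond donors and joins the aromatic ring through oxygen rather than nitrogen. Placing (oxan-4-yl)oxy where hydrogen stood gives a 15-fold lower number from compound 1 to compound 3 (1.17 log units; beyond the scatter) and lies beyond the scatter, in the same direction as the step already seen with 3-methylpiperazin-1-yl, so among these three compounds both substituted compounds give lower numbers than compound 1, and none goes against this. Nothing available explains why these two different groups give numbers within the scatter of each other.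

The compounds shown leave open whether the six-membered ring is needed at all or whether a smaller group on this carbon, such as methoxy or dimethylamino, would serve as well. They also leave open whether the methyl group of 3-methylpiperazin-1-yl matters, which an unsubstituted piperazin-1-yl group would test, and how a carboxylic acid at this position would behave.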